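The source may report more compounds than this note shows. Statements on the series, on what has been measured and on what is new or still open speak of the compounds shown alone.

Compound 1 `c1ccc(N/N=C(\N=N\c2nnnn2-c2ccccc2)c2ccccc2)cc1` carries the shared core with an unsubstituted phenyl ring on the hydrazone side. In an assay on lung for inhibition of Endothelin-converting enzyme 1 (Rattus norvegicus) (on this read-out higher numbers stand for weaker inhibition and lower numbers for stronger inhibition), compound 1 gives 10000 nM. Compound 2 `CCc1ccc(N/N=C(\N=N\c2nnnn2-c2ccccc2)c2ccccc2)cc1` gives 3800 nM in this assay, and compound 3 `CC(C)c1ccc(N/N=C(\N=N\c2nnnn2-c2ccccc2)c2ccccc2)cc1` gives 3400 nM. The steps run as follows: a 2.6-fold lower number from compound 1 to compound 2 (0.42 log units; beyond the scatter), a 2.9-fold lower number from compound 1 to compound 3 (0.47 log units; beyond the scatter), and a 1.1-fold lower number from compound 2 to compound 3 (0.05 log units; within the scatter). Compound 3 thus shows the lowest number of the three, separated from compound 1 by a step beyond the scatter, while its gap to compound 2 lies within the scatter, so no order between compound 2 and compound 3 can be read from these numbers.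

Compound 4 `CCC(C)c1ccc(N/N=C(\N=N\c2nnnn2-c2ccccc2)c2ccccc2)cc1` differs from compound 3 by methyl in place of hydrogen on a saturated chain carbon, two bonds along the chain from an aromatic carbon. For the measured compounds named here, the step that bears most directly on this change is the one from compound 2 to compound 3, which added a methyl on the chain carbon bound to the aromatic carbon and stayed within the scatter. The larger gains came only when a chain was first placed on the ring, as seen from compound 1 to compound 2 and from compound 1 to compound 3. A further methyl out along the chain is therefore expected to give no step beyond the scatter in this assay, so compound 4 is expected to show a 1.1-fold lower number from compound 3 to compound 4 (0.05 log units; within the scatter). Compound 4 is estimated at 3000 nM, with a range from 1500 nM to 6000 nM.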

Compound 4, half-maximal inhibitory concentration: 2700 nM
The estimate for compound 4 lay 1.1-fold (0.05 log units) above the measured number; measured number inside the range.
By their numbers in this assay, from the lowest: compounds 4, 3 and 2 (each within the scatter of the next); then compound 1.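

In this assay, for the compounds shown here, the change from isopropyl to sec-butyl, with a methyl in place of hydrogen on a saturated chain carbon two bonds along the chain from an aromatic carbon, gives a 1.3-fold lower number from compound 3 to compound 4 (0.10 log units; within the scatter) and so adds no step that can be told from the scatter. The comparison with the ethyl compound, a 1.4-fold lower number from compound 2 to compound 4 (0.15 log units; within the scatter), points the same way, so ethyl, isopropyl and sec-butyl cannot be put in any order here, and extending the branch further out along the chain adds nothing readable to what the chain-carbon methyl of compound 3 had already shown. The only readable separation remains the one from the unsubstituted compound, a 3.7-fold lower number from compound 1 to compound 4 (0.57 log units; beyond the scatter), and no measurement shown here offers a reason for either the gain from compound 1 or the flat stretch among the three chain-bearing compounds.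

The compounds shown leave open whether a longer chain such as n-hexyl, or a bulkier group such as tert-butyl, would move the number beyond the scatter of this series. They also leave open whether an amine or a carboxylic acid at this chain carbon would shift it in either direction.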